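Changing the aromatic group on the shared core

The source may report more compounds than this note shows. Statements on the series, on what has been measured and on what is new or still open speak of the compounds shown alone.

Measured so far:
compound 1 `Cc1nc(-c2nc([C@@H](O)[C@H](O)[C@H](O)CO)c[nH]2)cs1`: 2.1 h
compound 2 `OC[C@@H](O)[C@@H](O)[C@H](O)c1c[nH]c(-c2cnccn2)n1`: 1.9 h

In an ADME assay on the whole organism (strain 129/SvEvBrd x C57BL/6) for metabolic stability, with Mus musculus as the target (a lower number here means that the compound disappears faster, a higher number that the compound lasts longer), compound 2 stands level with compound 1, as their two values lie within the scatter of each other. The next structure is compound 3 `Cn1cnc(-c2nc([C@@H](O)[C@H](O)[C@H](O)CO)c[nH]2)c1`, and the change is 1-methyl-1H-imidazol-4-yl in place of pyrazin-2-yl on an aromatic carbon. Among the measured compounds shown here, only one measured step bears on this change: a 1.1-fold lower number from compound 1 to compound 2 (0.04 log units; within the scatter). That step exchanged one aromatic group for another at the same place on the shared core, and its size stayed within the scatter. For the measured compounds named here, it is thin evidence, as no measured compound carries 1-methyl-1H-imidazol-4-yl. In this assay, no step beyond the scatter is therefore expected, and the expected step is a 1.1-fold higher number from compound 2 to compound 3 (0.02 log units; within the scatter). For compound 3, the estimated half-life is 2 h, with an expected range of 1 h to 3.8 h.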

Compound 3, half-life: 1.6 h
Beside the measured number, compound 3's estimate is 1.3-fold (0.10 log units) above it, and the stated range covers the measured number.
By their numbers in this assay, from the lowest: compounds 3, 2 and 1 (each within the scatter of the next).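

In this assay, a five-membered aromatic ring takes the place of a six-membered one with a 1.2-fold lower number from compound 2 to compound 3 (0.07 log units; within the scatter), and one five-membered aromatic group replaces another with a 1.3-fold lower number from compound 1 to compound 3 (0.12 log units; within the scatter). Pyrazin-2-yl, 2-methyl-1,3-thiazol-4-yl and 1-methyl-1H-imidazol-4-yl therefore stand level at this place, so neither ring size nor the choice among these three groups separates the compounds in this assay. No measurement at hand explains why the three stay level.

Open, going by these compounds, is whether an amine, a carboxylic acid or a longer alkyl chain at this place would shift the half-life beyond the scatter. Also open, on these data alone, is whether a change in the group of 8 heavy atoms, rather than in the aromatic group, would do so.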